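Swapping the aryl group on a thioether-linked propargylamine

The source may hold more compounds than are shown below. What is called first, only, known or untested is meant among the compounds shown, and "the series" means these compounds.

Compound 1 `C#CCNC1CCc2c(SCCc3cccc(C)c3)cccc21` gives 0.35 nM in an assay on isolated protein for inhibition of Amine oxidase [flavin-containing] B (Homo sapiens); a higher number here means a weaker inhibitor, a lower number a stronger inhibitor.
Compound 2 `C#CCNC1CCc2c(OCc3cccc(C(F)(F)F)c3)cccc21` gives 6410 nM.
Compound 3 `C#CCNC1CCc2c(SCCc3cccc(C(F)(F)F)c3)cccc21` gives 3720 nM.

Compound 1 has the lowest number of the three, so it is the strongest inhibitor here. Its nearest neighbour is compound 3, reached by an 11000-fold higher number from compound 1 to compound 3 (4.03 log units; beyond the scatter), a change that sits on the same aryl ring. Compound 2, with an ether in place of the thioether and the same trifluoromethyl group, lies even further away on the numbers shown.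

Compound 4 `C#CCNC1CCc2c(SCCc3ccc(OC)cc3)cccc21` has not yet been measured. Relative to compound 1 it carries 4-methoxyphenyl in place of 3-methylphenyl on a saturated chain carbon, two bonds along the chain from a sulfur. Within the data shown here, no measured step exactly matches this change; the only step available, an 11000-fold higher number from compound 1 to compound 3 (4.03 log units; beyond the scatter), shows that a single alteration on this aryl ring can move the number by a very large amount. That single step is all the guidance there is, so compound 4 is expected to fall between the extremes, most likely weaker than compound 1.

For compound 4 the estimated value is 30 nM, within a range from 2 nM to 500 nM, which corresponds to the expected step of an 86-fold higher number from compound 1 to compound 4 (1.93 log units; beyond the scatter).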

Compound 4, half-maximal inhibitory concentration: 62000 nM
For compound 4 the middle estimate is 2100-fold (3.32 log units) below the measured one; the measured number lies above the stated range.
By their numbers in this assay, from the lowest: compound 1; then compounds 3 and 2 (each within the scatter of the next); then compound 4.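

In this assay, this position has now given two very large steps, an 11000-fold higher number from compound 1 to compound 3 (4.03 log units; beyond the scatter) and a 180000-fold higher number from compound 1 to compound 4 (5.25 log units; beyond the scatter), and the second is the largest shown. Among compounds 1, 3 and 4, only the 3-methylphenyl group of compound 1 gives a low number, so the activity here depends strongly on this aryl group. Unlike the earlier step, this one alters two things at once, the group on the ring and its numbered place, and nothing shown explains the size of either step.

The compounds shown leave open which of those two alterations matters more. A 3-methoxyphenyl or a 4-methylphenyl group on the same chain would separate them, while an unsubstituted phenyl group would show what the methyl group of compound 1 contributes.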